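The compounds below may be only part of what the source reports. "The series", "measured", "known", "first", "only" and "open" are said of these compounds alone.

Measured in an ADME assay on T29 cells (Homo sapiens) for cytotoxicity, read by sulforhodamine B assay, with a stated time of 3 days; on this read-out lower numbers stand for stronger inhibition and higher numbers for weaker inhibition:
- compound 1 `Cc1ccc(Cn2cc(CO)c3ccccc32)cc1`: > 31600 nM, a limit of the assay
- compound 2 `OCc1cn(Cc2ccc(Cl)cc2)c2ccc(F)cc12`: 8120 nM

Within the data shown here, compound 2 holds the only true number so far, 8120 nM. Compound 3 `Cc1ccc(Cn2cc(CO)c3cc(F)ccc32)cc1` differs from it by methyl in place of chloro on an aromatic carbon. That methyl also occurs in compound 1. Compound 1 gives only a limit, > 31600 nM. Among the measured compounds shown here, no measured single-change step exists, so the expectation is loose: somewhat weaker inhibition in this assay, slightly beyond the scatter. The expected change is a 2.2-fold higher number from compound 2 to compound 3 (0.35 log units; beyond the scatter). Compound 3 is estimated at 18000 nM, within a range of 7000 nM to 31600 nM.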

Compound 3, half-maximal inhibitory concentration: 11700 nM
The estimate for compound 3 lay 1.5-fold (0.19 log units) above the measured number; the range from low to high includes it.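

In this assay, methyl in place of chloro, para to a large group, gives a 1.4-fold higher number from compound 2 to compound 3 (0.16 log units; within the scatter), so this assay does not tell the two groups apart at this position. Fluoro in place of hydrogen on an aromatic carbon gives an at least 2.7-fold lower number from compound 1 to compound 3 (0.43 log units; beyond the scatter), the only step here beyond the scatter. Its size stays open-ended, as compound 1 gives only a limit: the limit of > 31600 nM in this assay, at which 1 of the 3 values shown sits.

On these data alone, whether an amine or a carboxylic acid at this position would also stay within the scatter of compound 2 remains open. So does the true size of the fluoro step.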